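The compounds below may be only part of what the source reports. "The series", "measured", "known", "first", "only" and "open" are said of these compounds alone.

Measured compounds:
- compound 1 `CCOCCn1c(N2CCN(C)CC2)nc2ccccc21`, in a functional assay on ileum for inhibition of histamine H1 receptor (Cavia porcellus) (a higher number here means a weaker inhibitor, a lower number a stronger inhibitor), compound 1 gives 10 nM
- compound 2 `CCCCOCCn1c(N2CCN(C)CC2)nc2ccccc21`, compound 2 gives 38 nM
- compound 3 `CCCCCN1CCCN(c2nc3ccccc3n2CCOCC)CC1`, compound 3 gives 7.4 nM

Compound 1 stands second highest of the three numbers in this assay. Its nearest neighbour is compound 3, whose number lies within the usual scatter of that of compound 1, so the two cannot be told apart; compound 2 gives a higher number, beyond the scatter.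

Compound 4 `CN1CCN(c2nc3ccccc3n2-c2ccccc2)CC1` has not yet been measured. It differs from compound 1 in one place: phenyl in place of 2-ethoxyethyl on an aromatic nitrogen. Among the measured compounds shown here, no measured step concerns this nitrogen. For the measured compounds named here, the only step available, a 3.8-fold higher number from compound 1 to compound 2 (0.58 log units; beyond the scatter), concerns a different place, where a longer chain made the inhibitor weaker. Since a flat aromatic ring replacing a flexible chain with an oxygen is not covered by any measured pair, the direction is uncertain; a modest weakening is expected, roughly a 3.0-fold higher number from compound 1 to compound 4 (0.48 log units; beyond the scatter). Compound 4 is therefore estimated at 30 nM in this assay, with a range from 5 nM to 200 nM.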

Compound 4, half-maximal inhibitory concentration: 760 nM
Compound 4: the middle estimate sits 25-fold (1.40 log units) below what was measured; the whole stated range lies below it.
By their numbers in this assay, from the lowest: compounds 3 and 1 (each within the scatter of the next); then compound 2; then compound 4.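

At this aromatic nitrogen, this assay shows a far larger change than any seen before: there is a 76-fold higher number from compound 1 to compound 4 (1.88 log units; beyond the scatter) when phenyl takes the place of 2-ethoxyethyl, and a 20-fold higher number from compound 2 to compound 4 (1.30 log units; beyond the scatter) when phenyl takes the place of 2-butoxyethyl. Both steps exceed a 3.8-fold higher number from compound 1 to compound 2 (0.58 log units; beyond the scatter) for the change within the chain, so among these compounds, replacing the whole chain with a ring weakens inhibition much more than lengthening the chain does. No measurement available here explains why this replacement has so large an effect.

Phenyl both removes the chain oxygen and brings in a ring, so the compounds shown cannot say which of these two differences matters. A plain butyl chain or a benzyl group on this nitrogen would help separate them.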